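Swapping methyl for chloro in a second cytotoxicity series

The compounds below may be only part of what the source reports. "The series", "measured", "known", "first", "only" and "open" are said of these compounds alone.

Measured compounds:
- compound 1 `CCn1cc(C(=O)O)c(=O)c2cc(F)c(N3CCN(CN4C(=O)/C(=N\NC(=S)NOC)c5cc(Cl)ccc54)CC3)cc21`: 193000 nM
- compound 2 `CCn1cc(C(=O)O)c(=O)c2cc(F)c(N3CCN(CN4C(=O)/C(=N\NC(=S)NOC)c5cc(C)ccc54)CC3)cc21`: 238000 nM
- compound 3 `CONC(=S)N/N=C1\C(=O)N(CN2CCN(c3ccccc3)CC2)c2ccc(C)cc21`: 276000 nM

All three values come from an ADME assay on MT4 cells (Homo sapiens) for cytotoxicity, read by spectrophotometry, with a stated time of 5 days; on this read-out higher numbers stand for lower toxicity in this test and lower numbers for higher toxicity in this test. In this assay compound 1 gives 193000 nM and compound 2 gives 238000 nM. The two share a core and differ in one place: chloro in place of methyl on an aromatic carbon. The step of a 1.2-fold lower number from compound 2 to compound 1 (0.09 log units; within the scatter) is within the scatter, so the two numbers cannot be told apart.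

Compound 3 is built on a different core, and the difference between the two cores is not broken down here. In this assay compound 3 gives 276000 nM. Its values stand close to those of compound 1 and compound 2, all within the scatter of one another.

Compound 4 `CONC(=S)N/N=C1\C(=O)N(CN2CCN(c3ccccc3)CC2)c2ccc(Cl)cc21` has not yet been measured. It differs from compound 3 in one place: chloro in place of methyl on an aromatic carbon. This is the same change as from compound 2 to compound 1, made at the same kind of place on a different core. Because the step of a 1.2-fold lower number from compound 2 to compound 1 (0.09 log units; within the scatter) was within the scatter, a step of about the same small size is expected from compound 3 to compound 4, namely a 1.2-fold lower number from compound 3 to compound 4 (0.09 log units; within the scatter). For compound 4 the estimated value in this assay is 224000 nM, expected to lie between 130000 nM and 400000 nM. The estimate rests on a single earlier instance of this change, so it is uncertain.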

Compound 4, half-maximal cytotoxic concentration: 267000 nM
Beside the measured number, compound 4's estimate is 1.2-fold (0.08 log units) below it; measured number inside the range.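

In this assay, putting chloro in place of methyl on the core of compound 3 gives a 1.0-fold lower number from compound 3 to compound 4 (0.01 log units; within the scatter), so the two numbers cannot be told apart. Set beside the earlier case, the swap reads the same on both cores, since neither step nor the gap between them rises above the usual noise of the test: the same change on two cores in this assay, a 1.2-fold lower number (0.09 log units; within the scatter) from compound 2 to compound 1 and a 1.0-fold lower number (0.01 log units; within the scatter) from compound 3 to compound 4, 1.2-fold (0.08 log units) apart, within the scatter of two such steps. This shows that, on these two cores and in this one cytotoxicity test, exchanging methyl for chloro leaves no readable mark on the number, but it does not show that a real effect of the change carries from one core to the other, as there is no real effect here to follow, and two pairs are a very small basis for any rule.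

The compounds shown leave open whether any other group at this place on the aromatic ring, such as a nitrile, a trifluoromethyl group or a plain hydrogen, would shift the number by more than the scatter on either core. They also leave open whether methyl and chloro would stay just as hard to tell apart on a third core or in a different kind of test.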